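Halogen swap on the benzylidene arm of the series

The source may report more compounds than this note shows. Statements on the series, on what has been measured and on what is new or still open speak of the compounds shown alone.

Compound 1 `C=C1CC[C@@H]2[C@](C)(CO)[C@H](O)CC[C@@]2(C)[C@@H]1/C=C/C1=C/C(=C/c2ccc(N(C)C)cc2)OC1=O` gives 70000 nM in an assay on isolated protein for inhibition of Maltase-glucoamylase (Homo sapiens); on this read-out lower numbers stand for stronger inhibition and higher numbers for weaker inhibition. Compound 2 `C=C1CC[C@@H]2[C@](C)(COC(=O)c3cccnc3)[C@H](OC(=O)c3cccnc3)CC[C@@]2(C)[C@@H]1/C=C/C1=C/C(=C\c2ccccc2)OC1=O` gives 16000 nM in this assay, and compound 3 `C=C1CC[C@@H]2[C@](C)(COC(=O)c3cccnc3)[C@H](OC(=O)c3cccnc3)CC[C@@]2(C)[C@@H]1/C=C/C1=C/C(=C\c2ccc(Cl)cc2)OC1=O` gives 6000 nM in this assay. Compound 3 thus holds the lowest number of the three measured; compound 2 is nearest to it and compound 1 furthest. Going by the values given here, the only step that differs in one place, a 2.7-fold lower number from compound 2 to compound 3 (0.43 log units; beyond the scatter), is also the only measured change on the aromatic ring of that arm. Compound 4 `C=C1CC[C@@H]2[C@](C)(COC(=O)c3cccnc3)[C@H](OC(=O)c3cccnc3)CC[C@@]2(C)[C@@H]1/C=C/C1=C/C(=C\c2cccc(Br)c2)OC1=O` differs from compound 3 by 3-bromophenyl in place of 4-chlorophenyl on a double-bonded chain carbon bound to a double-bonded ring carbon. Among the compounds with values here, no measured step exchanges one halogen for another or changes where a halogen sits on this ring; the one step that bears on the change, a 2.7-fold lower number from compound 2 to compound 3 (0.43 log units; beyond the scatter), shows only that adding a halogen lowered the number, and compound 4 keeps a halogen. The move from compound 3 to compound 4 is therefore expected to stay within the scatter, a 1.3-fold higher number from compound 3 to compound 4 (0.12 log units; within the scatter), with at most a slight lean to a higher number in this assay. Compound 4 is estimated at 8000 nM in this assay, within 3000 nM to 22000 nM.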

Compound 4, half-maximal inhibitory concentration: 14000 nM
For compound 4 the middle estimate is 1.8-fold (0.24 log units) below the measured one; low and high end bracket the measured number.
By their numbers in this assay, from the lowest: compound 3; then compounds 4 and 2 (each within the scatter of the next); then compound 1.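

With 3-bromophenyl on the double-bonded chain carbon, a 1.1-fold lower number from compound 2 to compound 4 (0.06 log units; within the scatter) in this assay and so the presence of a halogen on this ring does not by itself carry the lower number. The swap of 4-chlorophenyl for 3-bromophenyl gives a 2.3-fold higher number from compound 3 to compound 4 (0.37 log units; beyond the scatter) and thus shows that this position responds to the identity or placing of the halogen, with the earlier 2.7-fold lower number from compound 2 to compound 3 (0.43 log units; beyond the scatter) now applying to 4-chlorophenyl and not to halogens in general. No measurement at hand explains this difference.

Halogen and ring placement change together in the swap, so the compounds shown do not separate their contributions. Also open, from the compounds shown here alone, is how an aromatic ring bearing a nitrile or a carboxylic acid would read at this position.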